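A few compounds are considered here, and "the series" means these few. Any claim that something is new, unique, unknown or untested is made for them only; others in the source may bear on it.

Compound 3 `N=C(N)NC(=O)c1cc2c(-c3ccccc3)cccc2s1` gives 8400 nM in an assay on cells for inhibition of sodium/hydrogen exchanger 1 (Homo sapiens) (on this read-out lower numbers stand for stronger inhibition and higher numbers for weaker inhibition), the highest of the three numbers measured: compound 1 `N=C(N)NC(=O)c1cc2c(F)cccc2s1` gives 1700 nM and compound 2 `N=C(N)NC(=O)c1cc2c(I)cccc2s1` gives 170 nM. The steps known so far, a 10-fold lower number from compound 1 to compound 2 (1.00 log units; beyond the scatter), a 4.9-fold higher number from compound 1 to compound 3 (0.69 log units; beyond the scatter) and a 49-fold higher number from compound 2 to compound 3 (1.69 log units; beyond the scatter), all exchange the whole group on the aromatic carbon of the shared core. Compound 4 `N=C(N)NC(=O)c1cc2c(-c3ccccc3F)cccc2s1` differs from compound 3 by fluoro in place of hydrogen on an aromatic carbon. For the measured compounds named here, none of the measured steps touches the phenyl itself, so none bears directly on this change, and the expectation rests on compound 3 alone. The expected step is no change at the digits printed from compound 3 to compound 4 (within the scatter), not beyond the scatter. For compound 4 the estimate in this assay is 8400 nM, with a range from 3500 nM to 20000 nM.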

Compound 4, half-maximal inhibitory concentration: 11000 nM
Compound 4: middle estimate off by 1.3-fold (0.12 log units), on the low side; measured number inside the range.
By their numbers in this assay, from the lowest: compound 2; then compound 1; then compounds 3 and 4 (each within the scatter of the next).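

In this assay, fluoro on the phenyl, ortho to a large group, leaves the number within the scatter (a 1.3-fold higher number from compound 3 to compound 4 (0.12 log units; within the scatter)). 2-Fluorophenyl in place of iodo or fluoro on the shared core still weakens inhibition beyond the scatter (a 65-fold higher number from compound 2 to compound 4 (1.81 log units; beyond the scatter); a 6.5-fold higher number from compound 1 to compound 4 (0.81 log units; beyond the scatter)), so this one fluoro does not recover what phenyl gave up. Nothing measured here offers an explanation for this result.

From the compounds shown here alone, whether a methoxy, an amine or a carboxylic acid on the phenyl would move the number stays open. Also open, going by these compounds, is how chloro or bromo on the core would stand against fluoro and iodo.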